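A few compounds are considered here, and "the series" means these few. Any claim that something is new, unique, unknown or untested is made for them only; others in the source may bear on it.

Measured in a functional assay on HeLa cells (Homo sapiens) for inhibition, read by sulforhodamine B assay, with a stated time of 48 h; a higher number here means a weaker inhibitor of growth, a lower number a stronger inhibitor of growth:
- compound 1 `COC(=O)[C@@]1(C)CCC=C2[C@@H]1CC[C@@H](C)[C@]2(C)Cc1c[nH]c2c(Br)cccc12` gives 13000 nM
- compound 2 `COC(=O)[C@@]1(C)CCC=C2[C@@H]1CC[C@@H](C)[C@]2(C)Cc1c[nH]c2c(Cl)cccc12` gives 14000 nM
- compound 3 `COC(=O)[C@@]1(C)CC[C@@H]2C3=C1CC[C@@H](C)[C@]3(C)C[C@@H]1c3cc(Br)ccc3N[C@H]21` gives 25000 nM

Compound 1 and compound 2 share a core and differ only by chloro in place of bromo on an aromatic carbon; that exchange made a 1.1-fold higher number from compound 1 to compound 2 (0.03 log units; within the scatter), so the two values sit together in this assay. Compound 3 carries a different core; the difference between the two cores is not broken down here, and its value in this assay lies close to both compound 1 and compound 2, with no gap beyond the scatter.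

Compound 4 `COC(=O)[C@@]1(C)CC[C@@H]2C3=C1CC[C@@H](C)[C@]3(C)C[C@@H]1c3cc(Cl)ccc3N[C@H]21` has not been measured. It differs from compound 3 by chloro in place of bromo on an aromatic carbon. This is the same kind of change as that from compound 1 to compound 2, though not the same: there the place is part of a fused or bridged system of two rings, ortho to a fused ring and meta to a fused ring, while here it is part of a fused or bridged system of five rings, meta to a fused ring and para to a fused ring.

Because the step of a 1.1-fold higher number from compound 1 to compound 2 (0.03 log units; within the scatter) was within the scatter, the step from compound 3 to compound 4 is expected to be about as small, a 1.1-fold higher number from compound 3 to compound 4 (0.03 log units; within the scatter). Compound 4 is therefore estimated at 27000 nM, expected between 12000 nM and 55000 nM.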

Compound 4, concentration for 50% growth inhibition: 23000 nM
Compound 4: middle estimate off by 1.2-fold (0.07 log units), on the high side, within the range that was stated.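

In this assay, chloro in place of bromo on an aromatic carbon gives a 1.1-fold lower number from compound 3 to compound 4 (0.04 log units; within the scatter) on the core of compound 3, and this step matches the earlier one on the core of compound 1: the same change on two cores in this assay, a 1.1-fold higher number (0.03 log units; within the scatter) from compound 1 to compound 2 and a 1.1-fold lower number (0.04 log units; within the scatter) from compound 3 to compound 4, 1.2-fold (0.07 log units) apart, within the scatter of two such steps. The exchange therefore carries across these two cores as a step within the scatter, even though it sits at a different place on each core. Among these compounds, this shows only that a small step stayed small on two cores; it does not show that a step of real size would carry over in the same way, nor that the agreement would hold on any other core or at any other place.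

The compounds shown hold only bromo or chloro on the aromatic ring, which leaves open how fluoro, methoxy or an amine would read there. The methyl ester is also the same in all four compounds, leaving open a carboxylic acid or an amide in its place.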